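Removing the acid: from 2-carboxyethenyl to vinyl

The source may hold more compounds than are shown below. What is called first, only, known or untested is meant among the compounds shown, and "the series" means these compounds.

Compound 3 `CC(C)(C)[Si](C)(C)O[C@@H]1CCCO[C@@H]1/C=C/C(=O)O` gives > 100000 nM in a functional assay on SW1573 cells (Homo sapiens) for antiproliferative activity, read by sulforhodamine B assay, with a stated time of 48 h (on this read-out lower numbers stand for stronger inhibition of growth and higher numbers for weaker inhibition of growth), which is a limit and not a number. Compound 1 `CC(C)(C)[Si](C)(C)O[C@@H]1CCCO[C@@H]1CO` gives > 100000 nM, also a limit. Compound 3 therefore stands at the limit of > 100000 nM in this assay, at which 2 of the 3 values shown sit. Going by the values given here, the only true number so far belongs to compound 2 `COC(=O)/C=C\[C@H]1OCCC[C@H]1O[Si](C)(C)C(C)(C)C`, at 6300 nM.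

Compound 4 `C=C[C@H]1OCCC[C@H]1O[Si](C)(C)C(C)(C)C` differs from compound 3 by vinyl in place of 2-carboxyethenyl on a saturated ring carbon, next to the ring oxygen.

Among the compounds with values here, two measured steps bear on this change, and both are large: an at least 15-fold lower number from compound 1 to compound 2 (1.20 log units; beyond the scatter), and an at least 15-fold higher number from compound 2 to compound 3 (1.20 log units; beyond the scatter). The third, a step that the two limits leave unreadable from compound 1 to compound 3, gives no size. The second step is the closest guide, since it also removes the 2-carboxyethenyl group. Within the data shown here, compound 4 also lacks the methoxycarbonyl part of compound 2, however, and no measured step tests that loss. A large move towards the number of compound 2 is therefore not assured, and a second limit remains possible.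

The expected change is an at least 5.0-fold lower number from compound 3 to compound 4 (0.69 log units; beyond the scatter), towards stronger inhibition of growth. For compound 4 the estimated value is 20000 nM, with an expected range from 5000 nM to 80000 nM.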

Compound 4, concentration for 50% growth inhibition: > 100000 nM
Compound 4: only a limit was reported (the forecaster's own chance of this, stated with the estimate: 30%); middle value at least 5.0-fold (0.69 log units) away from the limit.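

In this assay compound 4 gives > 100000 nM, which is a limit and not a number. The one readable step is an at least 15-fold higher number from compound 2 to compound 4 (1.20 log units; beyond the scatter), which shows that at this position, on a saturated ring carbon next to the ring oxygen, removing the 2-carboxyethenyl group in favour of vinyl does not bring the series to the level of compound 2, so the presence of the acid alone does not separate compound 3 from compound 2, and 2-(methoxycarbonyl)ethenyl remains the only group shown here that gives a true number. The steps from compound 3 and from compound 1 to compound 4 cannot be read, both ends being limits, and the flat end of the series now holds most of the compounds: the limit of > 100000 nM in this assay, at which 3 of the 4 values shown sit.

Still open, from the compounds shown here alone, is whether the activity of compound 2 depends on the methyl ester as such, or whether an ethyl ester, a primary amide or a longer chain ending in a methyl ester at the same carbon would also give a number. Going by these compounds, how far compound 1, compound 3 and compound 4 actually differ from one another also remains unknown, as all three sit at a limit.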